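Replacing the dimethoxyphenyl group on the shared core

The source may report more compounds than this note shows. Statements on the series, on what has been measured and on what is new or still open speak of the compounds shown alone.

In a functional assay on K562 cells (Homo sapiens) for antiproliferative activity, read by MTT assay, with a stated time of 48 h (on this read-out higher numbers stand for weaker inhibition and lower numbers for stronger inhibition), compound 2 `COc1ccc(CN2C(=O)C(=O)c3cc(-c4ccc(OC)c(OC)c4)ccc32)cc1` gives 260 nM, and compound 1 `COc1ccc(CN2C(=O)C(=O)c3cc(-c4cc(OC)cc(OC)c4)ccc32)cc1` gives 510 nM. Going by the values given here, these are the only two numbers so far and they lie within the scatter of each other, so neither can be ranked above the other.

Next in the series is compound 3 `COc1ccc(CN2C(=O)C(=O)c3cc(-c4ccc(F)cc4)ccc32)cc1`, which differs from compound 2 only in one group: 4-fluorophenyl in place of 3,4-dimethoxyphenyl on an aromatic carbon, (4-fluorophenyl in place of 3,4-dimethoxyphenyl on an aromatic carbon).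

Among the compounds with values here, one measured step bears on this change: a 2.0-fold lower number from compound 1 to compound 2 (0.29 log units; within the scatter). It exchanges 3,5-dimethoxyphenyl for 3,4-dimethoxyphenyl at the same place and stays within the scatter. It shows only that this rearrangement of the aryl group left no clear mark on the read-out. Within the data shown here, no measured compound carries fluorine or lacks both methoxy groups, so the evidence for this change is thin.

No step beyond the scatter is therefore expected in this assay, and no direction can be firmly assigned. The expected size is a 1.5-fold higher number from compound 2 to compound 3 (0.19 log units; within the scatter). For compound 3 the estimated value is 400 nM, with an expected range of 120 nM to 1400 nM.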

Compound 3, half-maximal inhibitory concentration: 240 nM
The estimate for compound 3 lay 1.7-fold (0.22 log units) above the measured number; low and high end bracket the measured number.
By their numbers in this assay, from the lowest: compounds 3, 2 and 1 (each within the scatter of the next, the first and the last beyond it).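

In this assay, going by these compounds alone, the change to compound 3 reads as a 1.1-fold lower number from compound 2 to compound 3 (0.03 log units; within the scatter) and so shows that this position can carry 4-fluorophenyl in place of 3,4-dimethoxyphenyl with no step that stands out from the scatter; neither methoxy group on this aryl ring is needed to keep the number in the range of compound 2. The series also gains its first step beyond the scatter, a modest one, in a 2.1-fold lower number from compound 1 to compound 3 (0.33 log units; beyond the scatter) but compound 2 lies within the scatter of both compound 1 and compound 3, so this step separates 4-fluorophenyl from 3,5-dimethoxyphenyl only and does not set up a graded order across all three aryl groups. Nothing measured on these compounds offers an explanation for either step.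

Still open, on these data alone, is whether the fluorine matters at all, which an unsubstituted phenyl or a 4-chlorophenyl group at the same place would help to settle. Also open, as far as these compounds go, is how this position responds to a group of a different kind, such as an amine, a carboxylic acid or a longer alkyl chain in place of the aryl ring.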